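Ring methylation across two butyne-linked imidazole cores

This account rests on a few compounds, and the source may have more. Where it says the series, first, only, none or still open, it means among the compounds named here.

Measured compounds:
compound 1, `CC(=O)N(C)C(C)C#CCn1ccnc1`: 3 mg/kg
compound 2, `CC(=O)N(C)C(C)C#CCn1ccnc1C`: > 100 mg/kg
compound 3, `Cn1ccn(CC#CCn2ccnc2)c1=O`: 3.7 mg/kg

In a functional assay on the whole organism for agonist activity, with Mus musculus as the target (a lower number here means that less compound is needed, a higher number that more compound is needed for the effect), compound 1 gives 3 mg/kg. Compound 2 carries a methyl in place of a hydrogen on the imidazole, the change being (methyl in place of hydrogen on an aromatic carbon). For compound 2 this assay reports only a limit, > 100 mg/kg, so the step is an at least 33-fold higher number from compound 1 to compound 2 (1.52 log units; beyond the scatter) and rests on the limit of > 100 mg/kg in this assay, at which 1 of the 3 values shown sits, rather than on a measured number. Compound 3 is built on a different core; the difference between the two cores is not broken down here. In this assay compound 3 gives 3.7 mg/kg, a value that sits within the scatter of compound 1.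

Compound 4, `Cc1cncn1CC#CCn1ccn(C)c1=O`, has not yet been tested. It is made from compound 3 by methyl in place of hydrogen on an aromatic carbon. This is the same kind of change as that from compound 1 to compound 2, but the place differs: in compound 2 the methyl stands between two ring nitrogen atoms, while in compound 4 it is next to the ring nitrogen and two ring bonds from the ring nitrogen. Among the measured compounds shown here, because the only comparable step is an at least 33-fold higher number from compound 1 to compound 2 (1.52 log units; beyond the scatter), a higher number is expected for compound 4, though the changed place leaves the size uncertain. For compound 4 the expected value in this assay is 30 mg/kg, within a range from 5 mg/kg to 150 mg/kg. The expected step is an 8.1-fold higher number from compound 3 to compound 4 (0.91 log units; beyond the scatter), smaller than the earlier one, with a real chance that only a limit is reported.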

Compound 4, dose for half-maximal effect: > 100 mg/kg
Compound 4 gave a limit, no number (the forecaster's own chance of this, stated with the estimate: 35%); middle value at least 3.3-fold (0.52 log units) away from the limit.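

On the core of compound 3, methyl in place of hydrogen on an aromatic carbon gives an at least 27-fold higher number from compound 3 to compound 4 (1.43 log units; beyond the scatter) in this assay, so the direction seen on the core of compound 1 holds on a second core, and the step is large on both. For compound 4 the result is only a limit of the assay, > 100 mg/kg, and it is the second limit among the compounds shown, so neither step has a measured upper end: the limit of > 100 mg/kg in this assay, at which 2 of the 4 values shown sit. Two cores and two ring places show that this change carried over once in this series, not that it would carry over to every core or every ring carbon, and the sizes of the two steps cannot be compared: the same change on two cores in this assay, an at least 33-fold higher number (1.52 log units; beyond the scatter) from compound 1 to compound 2 and an at least 27-fold higher number (1.43 log units; beyond the scatter) from compound 3 to compound 4; the limit leaves it open whether they differ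

The compounds shown leave open how far the number lies beyond the limit for compound 2 and compound 4, since a measured value exists for neither. They also leave open whether a group other than methyl on these ring carbons, such as fluorine, an ethyl chain or an amine, would give a number close to that of the unsubstituted compounds or a similarly large step.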